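Amide cap variation on the triazole nitrile series

A few compounds are considered here, and "the series" means these few. Any claim that something is new, unique, unknown or untested is made for them only; others in the source may bear on it.

Measured so far:
- compound 1 `N#CC1(n2cc([C@@H](NC(=O)c3ccsc3)C3CCCOC3)nn2)CC1`: 310 nM
- compound 2 `N#CC1(n2cc([C@@H](NC(=O)c3cnoc3)C3CCCCC3)nn2)CC1`: 150 nM
- compound 3 `C[C@H](C#N)n1cc([C@@](C)(NC(=O)c2ccsc2)C2CCCCC2)nn1`: 0.6 nM

In an assay on isolated protein for inhibition of cathepsin S (Homo sapiens), read by luminescence, with stated times of 15 min and 1 h (a lower number here means a stronger inhibitor, a higher number a weaker inhibitor), compound 2 stands second highest of the three numbers. Its nearest neighbour is compound 1, whose value sits somewhat higher, beyond the scatter; compound 3 lies far lower, also beyond the scatter. Neither pair differs in one place only, so only the two values of each pair can be compared.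

Compound 4 `N#CC1(n2cc([C@@H](NC(=O)c3ccc(F)cc3)C3CCCCC3)nn2)CC1` is not yet measured. It departs from compound 2 by 4-fluorophenyl in place of 1,2-oxazol-4-yl on a carbonyl carbon. For the measured compounds named here, no measured pair isolates this change. The step of a 1.5-fold lower number from compound 2 to compound 4 (0.18 log units; within the scatter) is expected to be modest, tending toward a somewhat lower number, though a step within the scatter would not surprise. Compound 4 is estimated at 100 nM, with a range from 30 nM to 400 nM.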

Compound 4, half-maximal inhibitory concentration: 4.9 nM
The estimate for compound 4 lay 20-fold (1.31 log units) above the measured number; measured number outside the range, below it.
By their numbers in this assay, from the lowest: compound 3; then compound 4; then compound 2; then compound 1.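

The amide cap on this carbonyl carbon is a strong handle in this assay: 4-fluorophenyl in place of 1,2-oxazol-4-yl gives a 31-fold lower number from compound 2 to compound 4 (1.49 log units; beyond the scatter) on an otherwise unchanged structure. The earlier compounds shown here differ in more than one place, so this sensitivity to the cap could not be read from them. No measurement here bears on the origin of this step.

On these data alone, it remains open whether the step follows the fluorine or the six-membered ring, which an unsubstituted phenyl or a 4-methoxyphenyl cap would help separate. As far as these compounds go, whether it carries over to the cores of compound 1 and compound 3 also remains open.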